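The compounds below may be only part of what the source reports. "The series", "measured", "known", "first", "only" and "open" are said of these compounds alone.

Measured compounds:
- compound 1, `COc1cc2c(Oc3ccc(NC(=O)c4cn(-c5ccccc5F)nn4)cc3F)ccnc2cc1OCCCN1CCCCC1` — 2770 nM
- compound 2, `COc1cc2c(Oc3ccc(NC(=O)c4cn(-c5c(Cl)cccc5Cl)nn4)cc3F)ccnc2cc1OCCCN1CCCCC1` — 150 nM

In a functional assay on A549 cells (Homo sapiens) for cytotoxicity, read by MTT assay, with a stated time of 72 h (on this read-out lower numbers stand for stronger inhibition and higher numbers for weaker inhibition), compound 1 gives 2770 nM. Compound 2 gives 150 nM in this assay. Going by the values given here, compound 1 therefore stands as the higher of the two numbers, that is, the weaker of the two at slowing the growth of the cancer cells, and the single measured step, an 18-fold lower number from compound 1 to compound 2 (1.27 log units; beyond the scatter), is a large one.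

Compound 3, `COc1cc2c(Oc3ccc(NC(=O)c4cn(-c5ccccc5F)nn4)cc3F)ccnc2cc1OCCCN1CCC(C)CC1`, is not yet measured. It differs from compound 1 at a quite different place: methyl in place of hydrogen on a saturated ring carbon. Among the compounds with values here, the only measured step changes the aryl group on the aromatic nitrogen at the far end of the molecule and leaves the saturated ring untouched, so it says nothing about what a small methyl on that ring will do. Within the data shown here, the data give no step that bears on this change at all.

With nothing to point either way, the expectation for compound 3 is a number close to that of compound 1, with the step of a 1.0-fold lower number from compound 1 to compound 3 (0.01 log units; within the scatter) expected to stay within the usual scatter. The estimate for compound 3 in this assay is 2700 nM, with a range from 1100 nM to 6500 nM.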

Compound 3, half-maximal inhibitory concentration: 250 nM
Compound 3: middle estimate off by 11-fold (1.03 log units), on the high side; measured number below the stated range.
By their numbers in this assay, from the lowest: compounds 2 and 3 (each within the scatter of the next); then compound 1.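

The 4-methylpiperidin-1-yl end of the molecule proves to be far from a silent part of the structure: in this assay, methyl in place of hydrogen on a saturated ring carbon, three ring bonds from the ring nitrogen, gives an 11-fold lower number from compound 1 to compound 3 (1.04 log units; beyond the scatter). Going by these compounds alone, until this result, the only step that could be read was a change of the aryl group on the aromatic nitrogen, so this is a second place in the molecule where one change moves the number by more than the scatter, and here the change is only a methyl. What lies behind this drop in the number cannot be told, as nothing measured here speaks to its cause.

From the compounds shown here alone, it remains open whether the effect belongs to methyl in particular, or whether an ethyl, a hydroxyl or a dimethylamino group on the same ring carbon, or a morpholin-4-yl in place of the whole piperidin-1-yl, would give a similar number. Also open, going by these compounds, is what the same methyl would do on compound 2, which carries the 2,6-dichlorophenyl group, and whether the two changes would add together.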